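Sulfamoyl in place of isopropyl(methylsulfonyl)amino: working notes

The source may hold more compounds than are shown below. What is called first, only, known or untested is meant among the compounds shown, and "the series" means these compounds.

For the measured compounds named here, the series so far rests on very little data from an ADME assay on Huh-7 cells (Homo sapiens) for cytotoxicity, with a stated time of 72 h; a lower number here means that less compound is tolerated, a higher number that more compound is tolerated. Compound 1 `CCS(=O)(=O)Nc1ccc2c(c1)S(=O)(=O)N=C(c1c(O)c(-c3cccs3)nn(CCC(C)C)c1=O)N2` gives > 33000 nM, which is a limit of the assay and not a number. Compound 2 `CC(C)CCn1nc(-c2cccs2)c(O)c(C2=NS(=O)(=O)c3cc(N(C(C)C)S(C)(=O)=O)ccc3N2)c1=O` has no value to place on the scale, and its entry reads "not determined" (no result reported). Going by the values given here, the only reference point for compound 2 is therefore the reading from compound 1, which amounts to the limit of > 33000 nM in this assay, at which 1 of the 2 values shown sits.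

Compound 3 `CC(C)CCn1nc(-c2cccs2)c(O)c(C2=NS(=O)(=O)c3cc(S(N)(=O)=O)ccc3N2)c1=O` carries sulfamoyl in place of isopropyl(methylsulfonyl)amino on an aromatic carbon, on a six-membered aromatic ring of carbon only that is part of a fused or bridged system of two rings. The counted change is sulfamoyl in place of isopropyl(methylsulfonyl)amino on an aromatic carbon.

Among the compounds with values here, no measured pair covers this exchange, so any expectation remains weakly anchored. No step beyond the usual scatter is expected in this assay, in either direction, and the expectation leans on compound 1 with the limit of > 33000 nM in this assay, at which 1 of the 2 values shown sits. For compound 3 the half-maximal cytotoxic concentration is estimated at 33000 nM, with an expected range of 15000 nM to 70000 nM.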

Compound 3, half-maximal cytotoxic concentration: > 33000 nM
Compound 3: only a limit was reported; the forecaster's own chance of this, stated with the estimate: 75%; the middle value lies on the limit itself.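

Compound 1 and compound 3 each rest on a limit and not a number, so no step between them can be read in this assay: the limit of > 33000 nM in this assay, at which 2 of the 3 values shown sit.

Left open are the actual half-maximal cytotoxic concentrations of compound 1 and compound 3, and where compound 2, which has no reported result, stands relative to either.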